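A few compounds are considered here, and "the series" means these few. Any claim that something is new, unique, unknown or untested is made for them only; others in the source may bear on it.

Working notes on the series. In an in vitro ADME assay on microsomes from liver (Homo sapiens) for pharmacokinetics, read by LC-MS, with a stated time of 10 min, tested at 1 uM (on this read-out higher numbers stand for fast clearance and lower numbers for slow clearance), compound 2 (`CN1C[C@H](C(=O)Nc2ccc(C(F)(F)F)cc2)[C@@H](c2ccc(/C=C/C(=O)Nc3ccccc3N)cc2)C1`) gives 6 mL/min/kg and compound 1 (`CN1C[C@H](C(=O)Nc2ccc(C3CC3)cc2)[C@@H](c2ccc(/C=C/C(=O)Nc3ccccc3N)cc2)C1`) gives 12 mL/min/kg. These are the only two measured points. The step between them is a 2.0-fold lower number from compound 1 to compound 2 (0.30 log units; within the scatter), so compound 2 does not stand clear of compound 1 on these numbers.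

Still unmeasured is compound 3 (`CN1C[C@H](C(=O)Nc2cccc(Cl)c2)[C@@H](c2ccc(/C=C/C(=O)Nc3ccccc3N)cc2)C1`), with the change 3-chlorophenyl in place of 4-(trifluoromethyl)phenyl on an amide-type nitrogen. Among the compounds with values here, only one measured step bears on this, the exchange of cyclopropyl for trifluoromethyl on an aromatic carbon, and its size stayed within the scatter. Within the data shown here, no measured compound carries the 3-chlorophenyl group, so the data give no direct reading on it. Among the measured compounds shown here, with that single step as the only guide, no shift beyond the scatter is expected in this assay, and no direction is firmly supported. The expected step is a 1.5-fold higher number from compound 2 to compound 3 (0.18 log units; within the scatter), an estimate that stays within the scatter. Compound 3 is expected at 9 mL/min/kg, with an estimated range of 4 mL/min/kg to 20 mL/min/kg.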

Compound 3, clearance: 7 mL/min/kg
For compound 3 the middle estimate is 1.3-fold (0.11 log units) above the measured one; low and high end bracket the measured number.
By their numbers in this assay, from the lowest: compounds 2, 3 and 1 (each within the scatter of the next).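

In this assay, the group on the amide-type nitrogen now differs in both its substituent and the ring position of that substituent, and 3-chlorophenyl in place of 4-(trifluoromethyl)phenyl gives a 1.2-fold higher number from compound 2 to compound 3 (0.07 log units; within the scatter) while 3-chlorophenyl in place of 4-cyclopropylphenyl gives a 1.7-fold lower number from compound 1 to compound 3 (0.23 log units; within the scatter) as the second reading of the same exchange. Within the data shown here, compound 1 and compound 2 showed only two 4-substituted phenyl groups, whereas compound 3 adds a 3-substituted one and all three numbers remain within the scatter of each other, so across these three groups this position shows no step that stands clear of repeat measurement. No measured information bears on why these numbers lie so close together.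

Compound 3 changes the substituent and its ring position at once, so the separate contributions of chlorine versus trifluoromethyl and of the 3- versus the 4-position stay unresolved. Also open, as far as these compounds go, is whether a phenyl ring carrying an amine or a carboxylic acid, or a saturated alkyl chain in place of the phenyl ring on the amide-type nitrogen, would produce a step beyond the scatter.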